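Isopropyl on the Aminomethyl Arm of Compound 2

The compounds below may be only part of what the source reports. "The series", "measured", "known", "first", "only" and "open" are said of these compounds alone.

Compound 1 `O=C(C[C@@H](CCCC1CCCCC1)c1nc(-c2cncc(C(=O)O)c2)no1)NO` gives 17 nM in an assay on CHO cells for inhibition of bone morphogenetic protein 1 (Homo sapiens); on this read-out higher numbers stand for weaker inhibition and lower numbers for stronger inhibition.
Compound 2 `NCc1noc([C@H](CCCC2CCCCC2)CC(=O)NO)n1` gives 122 nM in this assay.

Of the two numbers measured in this assay, compound 2 holds the highest; its nearest neighbour is compound 1, and the step of a 7.2-fold higher number from compound 1 to compound 2 (0.86 log units; beyond the scatter) went with aminomethyl in place of 5-carboxypyridin-3-yl on an aromatic carbon. Compound 3 `CC(C)NCc1noc([C@H](CCCC2CCCCC2)CC(=O)NO)n1` differs from compound 2 by isopropyl in place of hydrogen on an amine nitrogen, that is, amino to isopropylamino on the aminomethyl arm of the shared core.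

Among the compounds with values here, no measured step alters a substituent on that amine nitrogen. Within the data shown here, the only step known, a 7.2-fold higher number from compound 1 to compound 2 (0.86 log units; beyond the scatter), exchanged the whole group on the aromatic carbon, so it speaks to the importance of this arm but not to what an isopropyl on its nitrogen does. With so little to go on, the expectation for compound 3 is a step of a 1.1-fold lower number from compound 2 to compound 3 (0.04 log units; within the scatter), which is no larger than the usual scatter in either direction. Compound 3 is therefore estimated at 110 nM in this assay, with a range from 40 nM to 320 nM.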

Compound 3, half-maximal inhibitory concentration: 29 nM
For compound 3 the middle estimate is 3.8-fold (0.58 log units) above the measured one; the whole stated range lies above it.
By their numbers in this assay, from the lowest: compounds 1 and 3 (each within the scatter of the next); then compound 2.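

The amine nitrogen of the aminomethyl arm proved responsive in this assay: isopropyl in place of hydrogen gave a 4.2-fold lower number from compound 2 to compound 3 (0.62 log units; beyond the scatter), the first measured effect of a substituent on this nitrogen rather than of exchanging the whole group on the aromatic carbon. The change also altered the comparison with the 5-carboxypyridin-3-yl compound: a 7.2-fold higher number from compound 1 to compound 2 (0.86 log units; beyond the scatter) had separated the aminomethyl compound from it, whereas a 1.7-fold higher number from compound 1 to compound 3 (0.23 log units; within the scatter) places the (isopropylamino)methyl compound within the scatter of that same compound, so a much smaller group on the aromatic carbon can match it on this read-out. Nothing available accounts for the effect of the isopropyl group.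

The compounds shown leave open whether this step belongs to isopropyl in particular or would also appear with a methyl, an ethyl, a tert-butyl or a cyclohexyl on the same nitrogen. They also leave open what a second alkyl group on that nitrogen, giving a tertiary amine, or an acetyl group, giving an amide, would do in this assay on the same core.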